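The source may hold more compounds than are shown below. What is called first, only, known or untested is meant among the compounds shown, and "the series" means these compounds.

Measured so far in a functional assay (aorta) with Oryctolagus cuniculus as the target; a higher number here means a weaker inhibitor, a lower number a stronger inhibitor:

Compound 1 `CO/C(O)=C1\C(C)=NC(C)=C(C(=O)OCCCN2C(=O)c3ccccc3S2(=O)=O)C1c1cccc([N+](=O)[O-])c1` gives 2.6 nM.
Compound 2 `CCO/C(O)=C1\C(C)=NC(C)=C(C(=O)OCCCN2C(=O)c3ccccc3S2(=O)=O)C1c1cccc([N+](=O)[O-])c1` gives 1.9 nM.
Compound 3 `CC1=NC(C)=C(C(=O)OCCCN2C(=O)c3ccccc3S2(=O)=O)C(c2cccc([N+](=O)[O-])c2)/C1=C(\O)OCC1CCCO1` gives 10.5 nM.

Compound 2 has the lowest number of the three. Its nearest neighbour is compound 1: the step of a 1.4-fold lower number from compound 1 to compound 2 (0.14 log units; within the scatter), so the two cannot be told apart. The furthest is compound 3: the step of a 5.5-fold higher number from compound 2 to compound 3 (0.74 log units; beyond the scatter), and in the same sense a 4.0-fold higher number from compound 1 to compound 3 (0.61 log units; beyond the scatter). All three measured compounds share one core and differ only in the group on a saturated chain carbon bound to an oxygen on an unsaturated carbon.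

Compound 4 `CCO/C(O)=C1\C(C)=NC(C)=C(C(=O)OCCCN2C(=O)c3ccccc3S2(=O)=O)C1c1ccccc1C(F)(F)F` changes a different part of the molecule: 2-(trifluoromethyl)phenyl in place of 3-nitrophenyl on a saturated ring carbon. None of the three measured steps touches this position, so none of them bears directly on the change; they only show that the shared core tolerates small edits at the ester end with at most modest shifts in this assay. Without a comparable step, the best-supported expectation is no change beyond the scatter, with a wide margin of doubt on either side: the expected step is a 1.6-fold higher number from compound 2 to compound 4 (0.20 log units; within the scatter). Compound 4 is therefore estimated at 3 nM, within a range of 0.7 nM to 13 nM.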

Compound 4, half-maximal inhibitory concentration: 0.8 nM
The estimate for compound 4 lay 3.8-fold (0.57 log units) above the measured number; measured number inside the range.
By their numbers in this assay, from the lowest: compound 4; then compounds 2 and 1 (each within the scatter of the next); then compound 3.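

In this assay, within the data shown here, the group on the saturated ring carbon turns out to matter, a point the earlier compounds could not address because they all carried 3-nitrophenyl there: 2-(trifluoromethyl)phenyl in place of 3-nitrophenyl gives a 2.4-fold lower number from compound 2 to compound 4 (0.38 log units; beyond the scatter), a modest step but one beyond the scatter. A low number at this position therefore does not depend on the nitro group or its two hydrogen-bond acceptors, since the entering group has no hydrogen-bond acceptors and the number still falls. Nothing shown here explains the step, and no supporting data bear on its cause.

This single swap changes both the substituent and where it sits on the phenyl ring, so the compounds shown cannot tell which of the two matters; 3-(trifluoromethyl)phenyl, 2-nitrophenyl and unsubstituted phenyl would be the groups to separate these effects. Going by these compounds, it also remains open whether the ester changes seen with 3-nitrophenyl would carry over to 2-(trifluoromethyl)phenyl, as this group appears only with the ester end of compound 2.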